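The source may hold more compounds than are shown below. What is called first, only, known or untested is meant among the compounds shown, and "the series" means these compounds.

Working notes on the series. Three members have been run in an ADME assay on RAW264.7 cells (Mus musculus) for cytotoxicity, read by MTT assay, with a stated time of 24 h, tested at 10 ug/mL; a lower number here means a stronger effect, a higher number a weaker effect of the compound at the concentration tested. Compound 1 `COc1cc(/C=C/C(=O)c2cccc(O)c2)ccc1O` gives 62.6%. Compound 2 `COc1ccc(/C=C/C(=O)c2ccc(OC)c(OC)c2)cc1OC` gives 60.4%, and compound 3 `COc1ccc(/C=C/C(=O)c2cccc(O)c2)cc1OC` gives 63.9%. All three numbers lie within the usual scatter of one another, so no order among them is read.

Compounds 3 and 1 differ in one place only: hydrogen in place of methyl on an oxygen on an aromatic ring The step this made in this assay was a number 1.3 percentage points lower from compound 3 to compound 1 (within the scatter).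

Compound 4 `COc1ccc(/C=C/C(=O)c2ccc(OC)c(OC)c2)cc1O` has not been measured. It differs from compound 2 as follows: hydrogen in place of methyl on an oxygen on an aromatic ring The place is the same word for word as in the change from compound 3 to compound 1, so this is the same change, made a second time; it occurs twice among the compounds shown. How the core of compound 2 differs from that of compound 3 is not broken down here.

The step from compound 2 to compound 4 in this assay is expected to be a number 0.9 percentage points lower from compound 2 to compound 4 (within the scatter), resting on compound 1 and the earlier step of a number 1.3 percentage points lower from compound 3 to compound 1 (within the scatter), which stayed within the scatter. Compound 4 is therefore estimated at 59.5%, with an expected range from 50% to 69%.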

Compound 4, a percentage reported as activity, at one concentration (the size of the read-out at that concentration, not a potency): 73.5%
Beside the measured number, compound 4's estimate is 14 percentage points below it; measured number outside the range, above it.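

Methoxy to hydroxy does not carry from one core to the other as a fixed step in this assay, and the two results differ: the same change on two cores in this assay, a number 1.3 percentage points lower (within the scatter) from compound 3 to compound 1 and a number 13.1 percentage points higher (beyond the scatter) from compound 2 to compound 4, 14.4 percentage points apart, beyond the scatter of two such steps. On the core of compound 2 the change gives a number 13.1 percentage points higher from compound 2 to compound 4 (beyond the scatter), whereas on the core of compound 3 its step stays within the scatter, so a step read on one of these cores is a poor guide to the size of the step on the other. With a single pair on each core, this shows that the outcome of the change differs between these two cores, but it does not show which feature of the cores goes with the difference, nor that hydroxy in place of methoxy raises the number in general.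

The compounds shown leave open which part of the difference between the two cores goes with the gap, and how the change reads on any further core. They also leave open how another group on that oxygen, such as a longer chain in place of methyl, or an amine in place of the hydroxy, would read in this assay.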